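Moving from Compound 3 to Compound 4 on the Shared Core

The source may report more compounds than this note shows. Statements on the series, on what has been measured and on what is new or still open speak of the compounds shown alone.

Compound 1 `O=C1CCC(c2ccc(NC(=O)CCl)cc2)=NN1` gives 0.39 ug/mL in a functional assay for inhibition, with Homo sapiens as the target; a lower number here means that less compound is needed, a higher number that more compound is needed for the effect.
Compound 2 `CCC(Cl)C(=O)Nc1ccc(C2=NNC(=O)CC2)cc1` gives 1.47 ug/mL in this assay.
Compound 3 `CC(C)(CCl)C(=O)Nc1ccc(C2=NNC(=O)CC2)cc1` gives 11.4 ug/mL in this assay.

Compound 3 stands highest of the three numbers in this assay; compound 2 is nearest to it and compound 1 furthest. Compound 4 `CCC(C)NCC(=O)Nc1ccc(C2=NNC(=O)CC2)cc1` is not yet measured. It differs from compound 3 in one place: ((sec-butyl)amino)methyl in place of 1-(chloromethyl)-1-methylethyl on a carbonyl carbon. Within the data shown here, two measured steps touch the same carbonyl carbon: a 29-fold higher number from compound 1 to compound 3 (1.47 log units; beyond the scatter) and a 7.8-fold higher number from compound 2 to compound 3 (0.89 log units; beyond the scatter). Among the measured compounds shown here, both rose as the group there grew, and the entering group is again the larger one, but no measured compound carries the entering group, so the data give no direct guide. A modest further rise is therefore expected, a 2.2-fold higher number from compound 3 to compound 4 (0.34 log units; beyond the scatter). Compound 4 is estimated at 25 ug/mL in this assay, within 6 ug/mL to 100 ug/mL.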

Compound 4, half-maximal effective concentration: about 21.5 ug/mL
The estimate for compound 4 lay 1.2-fold (0.07 log units) above the measured number; the measured number falls inside the stated range.
By their numbers in this assay, from the lowest: compound 1; then compound 2; then compounds 3 and 4 (each within the scatter of the next).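

In this assay, compound 4 is the only compound shown without a chlorine, and replacing 1-(chloromethyl)-1-methylethyl with ((sec-butyl)amino)methyl on the carbonyl carbon gives a 1.9-fold higher number from compound 3 to compound 4 (0.28 log units; within the scatter), so the two groups cannot be told apart. Both groups stand well apart from the smaller ones, with a 15-fold higher number from compound 2 to compound 4 (1.17 log units; beyond the scatter) and a 55-fold higher number from compound 1 to compound 4 (1.74 log units; beyond the scatter), so dropping chlorine for a nitrogen-bearing chain does not bring back the low numbers. No measurement shown explains this result.

On these data alone, it remains open whether the sec-butyl part or the amine nitrogen sets the number. A methylamino group in place of chloro would help to separate the two.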